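Furan to thiophene swap across two nucleoside cores

The source may report more compounds than this note shows. Statements on the series, on what has been measured and on what is new or still open speak of the compounds shown alone.

Working notes on the series, read in an ADME assay on BJ cells (Homo sapiens), read by MTT assay, with a stated time of 72 h; on this read-out higher numbers stand for weaker inhibition and lower numbers for stronger inhibition. Compound 1 `Cc1nc(N)c2c(-c3cccs3)cn([C@@H]3O[C@H](CO)[C@@H](O)[C@H]3O)c2n1` carries thiophen-2-yl, and compound 2 `Cc1nc(N)c2c(-c3ccco3)cn([C@@H]3O[C@H](CO)[C@@H](O)[C@H]3O)c2n1` carries furan-2-yl on the same core. Compound 3 `Nc1nc2c(c(-c3ccco3)cn2[C@@H]2O[C@H](CO)[C@@H](O)[C@H]2O)c(=O)[nH]1` carries furan-2-yl on a second core, and compound 4 `Nc1nc2c(c(-c3cccs3)cn2[C@@H]2O[C@H](CO)[C@@H](O)[C@H]2O)c(=O)[nH]1`, not yet measured, carries thiophen-2-yl on the core of compound 3. How the core of compound 3 differs from that of compound 2 is not broken down here.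

In this assay compound 1 gives > 100000 nM, which is a limit of the assay and not a number. Compound 2 gives > 100000 nM, again a limit. Compound 3 gives > 100000 nM, likewise a limit.

The change from compound 2 to compound 1 is thiophen-2-yl in place of furan-2-yl on an aromatic carbon. Its size is a step that the two limits leave unreadable from compound 2 to compound 1, so the measured pair says nothing about the direction of the swap.

Within the data shown here, the change from compound 3 to compound 4 is thiophen-2-yl in place of furan-2-yl on an aromatic carbon, and since both place descriptions are identical, it is the same change as the one between compound 2 and compound 1. The step from compound 3 to compound 4 is estimated as a step that the limit leaves unreadable from compound 3 to compound 4, resting on (the limit of > 100000 nM in this assay, at which 3 of the 3 values shown sit), which gives no sign that the swap moves any compound away from the limit. Compound 4 is therefore expected to sit at about 150000 nM, within 50000 nM to 500000 nM, and most probably to be reported as a limit again.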

Compound 4, half-maximal inhibitory concentration: > 100000 nM
Compound 4: no number, only a limit; the forecaster's own chance of this, stated with the estimate: 85%; the middle value does not contradict the limit.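

In this assay compound 4 gives > 100000 nM, which is a limit of the assay and not a number. Compound 3 also stands at a limit, so no step can be read from compound 3 to compound 4.

The compounds shown leave open whether thiophen-2-yl in place of furan-2-yl shifts this read-out on either core, and where any of the four compounds truly lies: the limit of > 100000 nM in this assay, at which 4 of the 4 values shown sit.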